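From 2-Chlorophenyl to 4-Fluorophenyl: One Small Step

The compounds below may be only part of what the source reports. "The series", "measured", "known", "first", "only" and "open" are said of these compounds alone.

Measured so far in a functional assay on A549 cells (Homo sapiens) for antiproliferative activity, read by MTT assay, with a stated time of 72 h; a lower number here means a stronger inhibitor, a higher number a weaker inhibitor:
compound 1 `Cc1ccc(N2CCN(C(=S)SCc3ccc4nc(N)nc(N)c4c3)CC2)c(C)c1`: 3000 nM
compound 2 `Nc1nc(N)c2cc(CSC(=S)N3CCN(c4ccccc4Cl)CC3)ccc2n1`: 3610 nM

Compound 2 gives 3610 nM, a value within the scatter of compound 1 at 3000 nM. The next compound to be tested in this assay is compound 3 `Nc1nc(N)c2cc(CSC(=S)N3CCN(c4ccc(F)cc4)CC3)ccc2n1`, which keeps the shared core. Among the compounds with values here, its one difference from compound 2 is 4-fluorophenyl in place of 2-chlorophenyl on an amine nitrogen in a ring.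

Within the data shown here, only one measured step bears on this place: a 1.2-fold higher number from compound 1 to compound 2 (0.08 log units; within the scatter). There, 2-chlorophenyl replaced 2,4-dimethylphenyl on the same nitrogen, and the values did not separate. Neither measured compound carries the 4-fluorophenyl group, and one step is thin evidence, so the range is kept wide. On the size of a 1.2-fold higher number from compound 1 to compound 2 (0.08 log units; within the scatter), no change beyond the scatter is expected, and no direction is favoured. The expected step is a 1.0-fold lower number from compound 2 to compound 3 (0.01 log units; within the scatter). For compound 3 the estimated value is 3500 nM, with an expected range from 1500 nM to 8000 nM.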

Compound 3, half-maximal inhibitory concentration: 2040 nM
For compound 3 the middle estimate is 1.7-fold (0.23 log units) above the measured one; measured number inside the range.
By their numbers in this assay, from the lowest: compounds 3, 1 and 2 (each within the scatter of the next).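

In this assay, the change to 4-fluorophenyl stays within the scatter, both against the 2-chlorophenyl group (a 1.8-fold lower number from compound 2 to compound 3 (0.25 log units; within the scatter)) and against the 2,4-dimethylphenyl group (a 1.5-fold lower number from compound 1 to compound 3 (0.17 log units; within the scatter)). Within the data shown here, three differently substituted phenyl groups on this amine nitrogen in a ring now give values that do not separate, where the earlier pair offered only a single comparison, so across these compounds the position shows no order among its groups. The step from 2-chlorophenyl to 4-fluorophenyl also replaces the halogen and moves the substituent on the phenyl ring in one change, so it cannot assign anything to either difference alone.

On these data alone, whether the values stay together with something other than a substituted phenyl on this nitrogen, such as an unsubstituted phenyl, a benzyl group, a pyridine ring or a plain methyl, remains open. No measurement of any property of these groups is available to account for the values shown.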